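Amide variation on the alkyne-linked anilinopyridopyrimidine series

The compounds below may be only part of what the source reports. "The series", "measured", "known", "first", "only" and "open" are said of these compounds alone.

Measured so far, in an assay on isolated protein for inhibition of MAP kinase-interacting serine/threonine-protein kinase 1 (Homo sapiens), read by HTRF, in the presence of a further agent that is not named here; a lower number here means a stronger inhibitor, a higher number a weaker inhibitor:
compound 1 `CCCNC(=O)c1oc2ccc(Nc3ncnc4ccc(Cl)nc34)cc2c1C`, a limit of > 10000 nM
compound 2 `CCCNC(=O)c1cccc(C#Cc2ccccc2Nc2ncnc3ccc(Cl)nc23)c1`, a limit of > 10000 nM
compound 3 `Cc1c(C(=O)N(C)C)oc2ccc(Nc3ncnc4ccc(Cl)nc34)cc12`, a limit of > 10000 nM

Compound 2 stands at the assay limit, with no number of its own. For the measured compounds named here, it shares that position with the other two measured compounds, all of which sit at the limit of > 10000 nM in this assay, at which 3 of the 3 values shown sit, so no compound in this set can be ranked against another.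

The next compound, compound 4 `CN(C)C(=O)c1cccc(C#Cc2ccccc2Nc2ncnc3ccc(Cl)nc23)c1`, differs from compound 2 in one place: dimethylamino in place of propylamino on a carbonyl carbon.

The same change, on the shared core of compound 1, is represented by a step that the two limits leave unreadable from compound 1 to compound 3; because both ends of that step sit at the limit, its size cannot be read. Going by the values given here, there is therefore no measured step that shows whether the dimethylamino group is tolerated better or worse than the propylamino group here. With compound 2 itself at the limit, the expectation for the step that the limit leaves unreadable from compound 2 to compound 4 is simply that compound 4 will also fail to reach a readable value. Compound 4 is estimated at 20000 nM, between 6000 nM and 60000 nM.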

Compound 4, half-maximal inhibitory concentration: > 10000 nM
Compound 4: only a limit was reported (the forecaster's own chance of this, stated with the estimate: 85%); the middle value does not contradict the limit.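

Compound 4, like compound 2, gives only a limit, so no size can be read for the step between the two: the limit of > 10000 nM in this assay, at which 4 of the 4 values shown sit.

From the compounds shown here alone, still open in this assay is whether dimethylamino or propylamino on the carbonyl carbon gives the stronger inhibitor, and which change to either shared core would bring a compound to a readable value.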